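Swapping Nitro for Trifluoromethyl on a Thiourea Core

The compounds below may be only part of what the source reports. "The series", "measured", "known", "first", "only" and "open" are said of these compounds alone.

Of the compounds shown here, three sharing the same core have been measured in an assay on isolated protein for binding affinity to stress-70 protein, mitochondrial (Homo sapiens); a higher number here means weaker binding, a lower number tighter binding. Compound 1 `CC1(C)CC[N+](C)(C)c2ccc(NC(=O)Nc3ccc([N+](=O)[O-])cc3)cc21` gives 700 nM. Compound 2 `CN1c2ccc(NC(=O)Nc3ccc(N)cc3)cc2C(C)(C)C(=O)C1(C)C` gives 1100 nM. Compound 3 `CN1c2ccc(NC(=S)Nc3ccc([N+](=O)[O-])cc3)cc2C(C)(C)C(O)C1(C)C` gives 2300 nM, the highest of the three numbers, which means that compound 3 binds the least tightly of the three. Its nearest neighbour on the numbers is compound 2, whose value is lower by more than the usual scatter, and the furthest is compound 1, lower still.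

Compound 4 `CN1c2ccc(NC(=S)Nc3ccc(C(F)(F)F)cc3)cc2C(C)(C)C(O)C1(C)C` has not yet been measured. It differs from compound 3 in one place: trifluoromethyl in place of nitro on an aromatic carbon. Among the measured compounds shown here, nothing among the measured compounds shows this exchange, so no measured step can guide the expectation; the two groups are simply of similar size and both lack hydrogen-bond donors. On that basis the step from compound 3 to compound 4 is expected to be small in this assay, with a slight lean towards a higher number. Compound 4 is therefore expected to give 2800 nM, with a likely range from 1100 nM to 7000 nM. This estimate corresponds to a step of a 1.2-fold higher number from compound 3 to compound 4 (0.09 log units; within the scatter), expected to stay within the usual scatter.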

Compound 4, dissociation constant: 2300 nM
Beside the measured number, compound 4's estimate is 1.2-fold (0.09 log units) above it; the range from low to high includes it.
By their numbers in this assay, from the lowest: compounds 1 and 2 (each within the scatter of the next); then compounds 3 and 4 (each within the scatter of the next).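

In this assay, the change from 4-nitrophenyl to 4-(trifluoromethyl)phenyl gives no change at the digits printed from compound 3 to compound 4 (within the scatter). Among the compounds shown here, this is the first pair here that differs in one place only, so it gives the first direct reading of this position: a group with hydrogen-bond acceptors gives way to one with none, and the binding number stays within the scatter, so for this pair, binding at the level seen does not depend on keeping nitro at this place. No measurement shown explains why the two groups read alike.

As far as these compounds go, both compounds of the pair share the same thiourea and the same core, so it remains open whether this exchange would read the same way on the urea of compound 1, with its different core. From the compounds shown here alone, it is also open whether a much different group at this place, such as a carboxylic acid, a nitrile or a longer chain like a butyl group, would keep the binding level or shift it beyond the scatter.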